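Side chain change from compound 3 to compound 4

The source may report more compounds than this note shows. Statements on the series, on what has been measured and on what is new or still open speak of the compounds shown alone.

In an ADME assay on microsomes from liver (Rattus norvegicus) for metabolic stability, read by LC-MS, with a stated time of 10 min, tested at 0.5 uM (a lower number here means that less of the compound is left, a higher number that more of the compound is left), compound 1 (`CCN1CCN(CCCN(C[C@H]2Cc3ccccc3CN2)[C@H]2CCCc3cccnc32)CC1`) gives 1%, compound 2 (`NC(=O)N1CCN(CCCN(C[C@H]2Cc3ccccc3CN2)[C@H]2CCCc3cccnc32)CC1`) gives 4% and compound 3 (`c1ccc2c(c1)CN[C@@H](CN(CCCN1CCN(C3CC3)CC1)[C@H]1CCCc3cccnc31)C2`) gives 2%. Compound 3 therefore stands within the scatter of both other compounds, and the three values cannot be ranked.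

The next structure is compound 4 (`c1ccc2c(c1)CN[C@@H](CN(CCCCN1CCNCC1)[C@H]1CCCc3cccnc31)C2`). The change from compound 3 is (piperazin-1-yl)methyl in place of 4-cyclopropylpiperazin-1-yl on a saturated chain carbon, three bonds along the chain from an amine nitrogen. In words, (piperazin-1-yl)methyl takes the place of 4-cyclopropylpiperazin-1-yl on a saturated chain carbon, three bonds along the chain from an amine nitrogen.

Among the compounds with values here, three measured steps bear on this change, all of them swaps on an amine nitrogen in a ring. They are a number 3 percentage points higher from compound 1 to compound 2 (within the scatter), a number 1 percentage points higher from compound 1 to compound 3 (within the scatter) and a number 2 percentage points lower from compound 2 to compound 3 (within the scatter). None of them alters the chain or leaves that nitrogen without a substituent, so their support is only indirect. With a number 1 percentage points higher from compound 1 to compound 3 (within the scatter) as the closest case, since it involves the cyclopropyl of compound 3, no step beyond the scatter is expected in this assay. The estimated size of the change is a number 1 percentage points higher from compound 3 to compound 4 (within the scatter). For compound 4 the estimated value is 3%, with an expected range from 0% to 10%.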

Compound 4, percent of the compound remaining: 15%
Estimate against measurement, compound 4: 12 percentage points below; measured number outside the range, above it.
By their numbers in this assay, from the lowest: compounds 1, 3 and 2 (each within the scatter of the next); then compound 4.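

In this assay the swaps on the amine nitrogen in the ring stayed within the scatter, but the change on the saturated chain carbon, three bonds along the chain from an amine nitrogen, yields steps beyond it: a number 13 percentage points higher from compound 3 to compound 4 (beyond the scatter) and a number 11 percentage points higher from compound 2 to compound 4 (beyond the scatter) and a number 14 percentage points higher from compound 1 to compound 4 (beyond the scatter) and all three are modest. The step is of similar size whichever group leaves, whether 4-cyclopropylpiperazin-1-yl, 4-carbamoylpiperazin-1-yl or 4-ethylpiperazin-1-yl, so the three earlier compounds act as one low group against compound 4. This region of the molecule therefore moves the read-out in a way that the ethyl, carbamoyl and cyclopropyl substituents on the ring nitrogen did not.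

The change joins two differences, the 2-(piperazin-1-yl)ethyl form of the chain and the loss of the substituent on the ring nitrogen, and the compounds shown cannot separate them: a piperazin-1-yl group on the shorter chain of compound 3, or (4-cyclopropylpiperazin-1-yl)methyl in this place, would divide the step between the two. Nothing shown here gives a measured reason for the step.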